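From Chlorophenyl to Methoxyphenyl on a Shared Core

The source may hold more compounds than are shown below. What is called first, only, known or untested is meant among the compounds shown, and "the series" means these compounds.

Three compounds have been measured in a functional assay on cells for positive allosteric modulation of metabotropic glutamate receptor 5 (Rattus norvegicus), read by calcium flux; on this read-out higher numbers stand for an effect only at larger amounts of compound and lower numbers for an effect already at smaller amounts:

compound 1 `O=C(Nc1cc(-c2ccccc2)nn1-c1ccccc1)c1ccccc1` gives 203 nM
compound 2 `O=C(Nc1cc(-c2ccccc2)nn1-c1ccccc1)c1cc([N+](=O)[O-])cc([N+](=O)[O-])c1` gives 65 nM
compound 3 `O=C(Nc1cc(-c2ccccc2Cl)nn1-c1ccccc1)c1ccccc1` gives 2290 nM

Compound 3 stands highest of the three numbers. Among the measured compounds shown here, its nearest neighbour is compound 1, the parent bearing an unsubstituted phenyl: the single change an 11-fold higher number from compound 1 to compound 3 (1.05 log units; beyond the scatter) separates them. Furthest away is compound 2, whose two nitro groups on the benzamide side give 65 nM against the value of compound 3, 2290 nM; no single step connects those two.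

Compound 4 `COc1cccc(-c2cc(NC(=O)c3ccccc3)n(-c3ccccc3)n2)c1` is the next variant at the same position: 3-methoxyphenyl in place of 2-chlorophenyl on an aromatic carbon. For the measured compounds named here, the only measured step that touches this ring is the one from compound 1 to compound 3, an 11-fold higher number from compound 1 to compound 3 (1.05 log units; beyond the scatter), which shows that a chloro at that position raised the number by a large margin. Removing the chlorophenyl in favour of a methoxyphenyl is therefore expected to bring the number back down, though nothing measured says how far a methoxy group itself will be tolerated. The step of a 4.6-fold lower number from compound 3 to compound 4 (0.66 log units; beyond the scatter) is the estimated outcome. For compound 4 the expected value in this assay is 500 nM, with a range from 120 nM to 2500 nM.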

Compound 4, half-maximal effective concentration: 600 nM
Compound 4: the middle estimate sits 1.2-fold (0.08 log units) below what was measured, within the range that was stated.
By their numbers in this assay, from the lowest: compound 2; then compound 1; then compound 4; then compound 3.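

In this assay the exchange of the 2-chlorophenyl group for the 3-methoxyphenyl group gives a 3.8-fold lower number from compound 3 to compound 4 (0.58 log units; beyond the scatter) and so takes back part of the rise seen with the chloro group, yet the unsubstituted phenyl of compound 1 is not matched, with a 3.0-fold higher number from compound 1 to compound 4 (0.47 log units; beyond the scatter) on the same read-out. The rise at this ring carbon is therefore not confined to the chloro group: both substituted rings shown, in compound 3 and compound 4, carry higher numbers than the plain phenyl, and no compound with a change on this ring goes against that, though the step with the methoxy group is the smaller of the two, modest against large. Nothing available explains why these groups differ in this way.

Compound 3 and compound 4 differ both in the group and in where it sits on the ring, so the two contributions remain unseparated, and a 3-chlorophenyl or a 2-methoxyphenyl group at this place would be needed to pull them apart. Also open, from the compounds shown here alone, is how an amine on this ring, such as a 3-aminophenyl group, or a longer chain in place of the methoxy would fall relative to compound 1.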